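Pyridinyl carbonyl series: removing the ring methyl

The source may report more compounds than this note shows. Statements on the series, on what has been measured and on what is new or still open speak of the compounds shown alone.

Measured so far in an ADME assay on HEK-293T cells (Homo sapiens) for cytotoxicity, read by MTT assay, with a stated time of 24 h; on this read-out higher numbers stand for lower toxicity in this test and lower numbers for higher toxicity in this test:
compound 1 `Cc1cccc(C(=O)n2c(-c3cn(-c4ccccc4)nc3-c3ccc(C(F)(F)F)cc3)nc3ccccc32)c1`: 154000 nM
compound 2 `O=C(c1cccnc1)n1c(-c2cn(-c3ccccc3)nc2-c2ccc(F)cc2)nc2ccccc21`: 216000 nM
compound 3 `Cc1cncc(C(=O)n2c(-c3cn(-c4ccccc4)nc3-c3ccc(C(F)(F)F)cc3)nc3ccccc32)c1`: 123000 nM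

Compound 3 holds the lowest of the three numbers in this assay, but its gaps to compound 1 and to compound 2 both fall inside the usual scatter, so no ordering among the three is claimed. Compound 4 `O=C(c1cccnc1)n1c(-c2cn(-c3ccccc3)nc2-c2ccc(C(F)(F)F)cc2)nc2ccccc21` differs from compound 3 by hydrogen in place of methyl on an aromatic carbon. Among the compounds with values here, the only measured step at the carbonyl-bearing ring, a 1.3-fold lower number from compound 1 to compound 3 (0.10 log units; within the scatter), stayed within the scatter, so a change at this ring has so far not moved the read-out. Within the data shown here, compound 2, which also bears the pyridin-3-yl group, gives 216000 nM in this assay, close to compound 3, though no single step links compound 2 to compound 4. No step beyond the scatter is therefore expected. The estimate for compound 4 in this assay is 150000 nM, with a range from 70000 nM to 320000 nM. The implied step a 1.2-fold higher number from compound 3 to compound 4 (0.09 log units; within the scatter) is expected to remain within the scatter.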

Compound 4, half-maximal cytotoxic concentration: 158000 nM
Compound 4: the middle estimate sits 1.1-fold (0.02 log units) below what was measured; low and high end bracket the measured number.
By their numbers in this assay, from the lowest: compounds 3, 1, 4 and 2 (each within the scatter of the next).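

In this assay, hydrogen in place of methyl on the pyridine ring gives a 1.3-fold higher number from compound 3 to compound 4 (0.11 log units; within the scatter), so this read-out does not separate the 5-methylpyridin-3-yl and pyridin-3-yl groups. The two other new comparisons also stay inside the scatter: a 1.0-fold higher number from compound 1 to compound 4 (0.01 log units; within the scatter) for pyridin-3-yl in place of 3-methylphenyl on the carbonyl carbon, and a 1.4-fold lower number from compound 2 to compound 4 (0.14 log units; within the scatter) for trifluoromethyl in place of fluoro on an aromatic carbon. Across these four compounds, neither the carbonyl-bearing ring nor the site carrying fluoro or trifluoromethyl has yet given a step beyond the scatter.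

From the compounds shown here alone, whether an amine, a carboxylic acid or a longer chain in place of the methyl would give such a step remains open. No measurement shown bears on the reason for the size of these steps.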